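Working notes on the tolyl-triazole series: methyl for methoxy

The compounds below may be only part of what the source reports. "The series", "measured", "known", "first", "only" and "open" are said of these compounds alone.

Measured so far:
compound 1 `C=C1C(=O)[C@]23C[C@@]1(O)CC[C@H]2c1ccc(OS(=O)(=O)c2ccc(C)cc2)c(C)c1[C@@H]3Cn1cc(-c2ccccn2)nn1` — 2830 nM
compound 2 `C=C1C[C@]23C[C@@]1(O)CC[C@H]2c1ccc(O)c(C)c1[C@@H]3Cn1cc(-c2ccc(C(F)(F)F)cc2)nn1` — a limit, > 20000 nM
compound 3 `COc1ccc(-c2cn(C[C@H]3c4c(ccc(OS(=O)(=O)c5ccc(C)cc5)c4C)[C@@H]4CC[C@@]5(C)C[C@]43CC5=O)nn2)cc1` — a limit, > 20000 nM

Within the data shown here, in a functional assay on SMMC-7721 cells (Homo sapiens) for cytotoxicity, read by MTT assay, with a stated time of 4 days (a lower number here means a stronger inhibitor, a higher number a weaker inhibitor), compound 1 gives 2830 nM and is the only compound of the three with a number. For compound 2 this assay reports only a limit, > 20000 nM. For compound 3 this assay likewise reports only a limit, > 20000 nM. Among the measured compounds shown here, compound 3 therefore stands at the limit of > 20000 nM in this assay, at which 2 of the 3 values shown sit, together with compound 2, and no step between measured compounds can be taken from these three.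

Compound 4 `Cc1ccc(-c2cn(C[C@H]3c4c(ccc(OS(=O)(=O)c5ccc(C)cc5)c4C)[C@@H]4CC[C@@]5(C)C[C@]43CC5=O)nn2)cc1` has not yet been measured. It differs from compound 3 only in methyl in place of methoxy on an aromatic carbon, that is, 4-methoxyphenyl becomes 4-methylphenyl on the triazole. For the measured compounds named here, no measured pair shows what this kind of change does, and the change is small by the counted atoms.

Since compound 3 itself sits at the limit, the step from compound 3 to compound 4 is expected to be none beyond the scatter, a number no higher from compound 3 to compound 4 (the limit leaves the size open), and compound 4 is expected most likely to come back as a limit again. As a working estimate, compound 4 is expected at 20000 nM in this assay, within 8000 nM to 50000 nM.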

Compound 4, half-maximal inhibitory concentration: > 20000 nM
Compound 4: a limit, no number (the forecaster's own chance of this, stated with the estimate: 70%); the middle value sits exactly at the limit.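

In this assay compound 3 and compound 4 are both limits and not numbers, and no step between them can be read: the limit of > 20000 nM in this assay, at which 3 of the 4 values shown sit.

The compounds shown leave open whether methyl in place of methoxy on an aromatic carbon changes the read-out at all, and how far either compound lies beyond the limit.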